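Swapping nitro for amino on a potent fluoro compound

The compounds below may be only part of what the source reports. "The series", "measured", "known", "first", "only" and "open" are said of these compounds alone.

Compound 1 `COc1ccc(/C(F)=C\c2cc(OC)c(OC)c(OC)c2)cc1O` gives 4 nM
Compound 2 `COc1ccc(/C(F)=C\c2cc(OC)c(OC)c(OC)c2)cc1[N+](=O)[O-]` gives 379 nM

In a functional assay on NCI-H460 cells (Homo sapiens) for cytotoxicity, read by sulforhodamine B assay, with a stated time of 72 h (a higher number here means a weaker inhibitor, a lower number a stronger inhibitor), compound 2 gives 379 nM, the higher of the two numbers, which makes it the weaker inhibitor of the pair. Compound 3 `COc1ccc(/C(F)=C\c2cc(OC)c(OC)c(OC)c2)cc1N` keeps the shared core and changes one group: amino in place of nitro on an aromatic carbon. This is amino in place of nitro on an aromatic carbon, ortho to a methoxy group.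

Within the data shown here, only one measured step bears on this change. Going by a 95-fold higher number from compound 1 to compound 2 (1.98 log units; beyond the scatter), nitro in place of hydroxy on that same carbon cost a large amount of potency, well beyond the scatter. Among the measured compounds shown here, removing the nitro may therefore win back much of that loss, although no compound with an amino group has been measured to show it. Compound 1, with hydroxy there, gives 4 nM and marks the likely lower end. A large step to a lower number is expected in this assay, probably stopping short of a full recovery. The estimated step is a 25-fold lower number from compound 2 to compound 3 (1.40 log units; beyond the scatter). For compound 3 the expected value is 15 nM, with an estimated range from 4 nM to 90 nM.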

Compound 3, half-maximal inhibitory concentration: 11.5 nM
Estimate against measurement, compound 3: 1.3-fold (0.12 log units) above, within the range that was stated.
By their numbers in this assay, from the lowest: compound 1; then compound 3; then compound 2.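

In this assay, amino in place of nitro on this aromatic carbon gives a 33-fold lower number from compound 2 to compound 3 (1.52 log units; beyond the scatter) and shows that the large loss seen with nitro can be almost wholly regained with a single change at this one position, leaving the rest of the shared core untouched. The recovery is not complete, however: amino in place of hydroxy gives a 2.9-fold higher number from compound 1 to compound 3 (0.46 log units; beyond the scatter) and, although this step is only modest, it lies beyond the scatter, so the position separates hydroxy from amino as well as both of these from nitro, with compound 1 lowest, then compound 3, then compound 2. No measurement available here explains why these three groups rank in this order.

What the compounds shown leave open is how far the amino nitrogen can be built on, for example whether a methylamino group, a dimethylamino group or an acetamide on this carbon would stay close to compound 3 or fall back towards compound 2. A carboxylic acid at the same place would test a quite different kind of group on this carbon.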